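Ester side groups and cytotoxicity: from compound 3 to compound 4

The compounds below may be only part of what the source reports. "The series", "measured", "known", "first", "only" and "open" are said of these compounds alone.

Values in a functional assay on HCT-116 cells (Homo sapiens) for cytotoxicity, read by sulforhodamine B assay, with a stated time of 72 h (a higher number here means a weaker inhibitor, a lower number a stronger inhibitor), for the measured compounds:
- compound 1 `C=C1C(=O)O[C@@H]2CC(C)=C([C@@H](C)CCCOC(C)=O)[C@@H](OC(=O)CN3CCCCC3)[C@H]12` gives 13900 nM as its value
- compound 2 `C=C1C(=O)O[C@@H]2CC(C)=C([C@@H](C)CCCOC(C)=O)[C@@H](OC(=O)COc3ccc(C(C)=O)cc3)[C@H]12` gives 40100 nM as its value
- compound 3 `C=C1C(=O)O[C@@H]2CC(C)=C([C@@H](C)CCCOC(C)=O)[C@@H](OC(=O)COc3cccc4cccnc34)[C@H]12` gives 12100 nM as its value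

Compound 3 stands at the low end of the three numbers, together with compound 1. Compound 4 `C=C1C(=O)O[C@@H]2CC(C)=C([C@@H](C)CCCOC(C)=O)[C@@H](OC(=O)c3cccc(F)c3)[C@H]12` has 3-fluorophenyl in place of ((quinolin-8-yl)oxy)methyl on a carbonyl carbon, and the counted change is 3-fluorophenyl in place of ((quinolin-8-yl)oxy)methyl on a carbonyl carbon with the rest of the structure kept.

Going by the values given here, the steps that bear on this are a 2.9-fold higher number from compound 1 to compound 2 (0.46 log units; beyond the scatter) and a 3.3-fold lower number from compound 2 to compound 3 (0.52 log units; beyond the scatter) as the modest ones, and a 1.1-fold lower number from compound 1 to compound 3 (0.06 log units; within the scatter) as the one that stays within the scatter. Among the compounds with values here, all three exchange a group on a saturated chain carbon bound to a carbonyl carbon, and no measured compound has a ring directly on that carbonyl carbon, so the evidence is indirect. Those steps span only a narrow range, which argues against a large shift. For compound 4 the expected step is a 1.7-fold higher number from compound 3 to compound 4 (0.22 log units; within the scatter) toward higher numbers. The estimated value for compound 4 is 20000 nM with 8000 nM to 48000 nM as the expected range.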

Compound 4, half-maximal inhibitory concentration: 14500 nM
The estimate for compound 4 lay 1.4-fold (0.14 log units) above the measured number, within the range that was stated.
By their numbers in this assay, from the lowest: compounds 3, 1 and 4 (each within the scatter of the next); then compound 2.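

In this assay, a ring placed directly on the carbonyl carbon leaves the number level with two of the earlier side groups: a 1.2-fold higher number from compound 3 to compound 4 (0.08 log units; within the scatter) and a 1.0-fold higher number from compound 1 to compound 4 (0.02 log units; within the scatter). The (4-acetylphenoxy)methyl group of compound 2 is the only one of the three that separates from 3-fluorophenyl, with a 2.8-fold lower number from compound 2 to compound 4 (0.44 log units; beyond the scatter), so this position accepts a directly attached fluorinated ring, a (piperidin-1-yl)methyl group and a ((quinolin-8-yl)oxy)methyl group without a readable difference among them. Nothing available explains these steps.

Whether the fluorine contributes at all stays open, since a plain phenyl ring on this carbonyl carbon is not among the compounds shown. Also open, from the compounds shown here alone, is how an amine or a carboxylic acid on that ring would read in this assay.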